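From compound 2 to compound 4: one group leaves

This account rests on a few compounds, and the source may have more. Where it says the series, first, only, none or still open, it means among the compounds named here.

Values so far in a functional assay on WiDr cells (Homo sapiens) for antiproliferative activity, read by sulforhodamine B assay, with a stated time of 48 h; on this read-out lower numbers stand for stronger inhibition of growth and higher numbers for weaker inhibition of growth
- compound 1 `CC(C)(C)[Si](C)(C)O[C@@H]1CCCO[C@@H]1CO` gives > 100000 nM (a limit, not a number)
- compound 2 `CC(C)(C)[Si](C)(C)O[C@H]1CCCO[C@@H]1COCC(=O)OCc1ccccc1` gives 28000 nM
- compound 3 `CC(C)(C)[Si](C)(C)O[C@@H]1CCCO[C@@H]1COCC(=O)OCc1ccccc1` gives 37000 nM

Within the data shown here, compound 2 has only one numerical neighbour, and the gap is a 1.3-fold higher number from compound 2 to compound 3 (0.12 log units; within the scatter). That small step concerns only (the fact that compounds 2 and 3 differ only in the configuration as drawn), so it says little about what follows.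

Compound 4 `O=C(COC[C@H]1OCCC[C@@H]1O)OCc1ccccc1` brings (a hydrogen atom in place of a group of 7 heavy atoms (6 carbon, 1 silicon; no ring), on an oxygen on a saturated carbon). Among the measured compounds shown here, no measured step makes this change. Compound 1 carries the same group and reaches a limit, > 100000 nM. The measured numbers already lie not far from the limit of > 100000 nM in this assay, at which 1 of the 3 values shown sits, so only a tentative expectation is possible, and this assay may return just a limit. The expected change is a 3.2-fold higher number from compound 2 to compound 4 (0.51 log units; beyond the scatter), towards weaker growth inhibition. For compound 4 the estimated value is 90000 nM, within an expected range from 35000 nM to 230000 nM.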

Compound 4, concentration for 50% growth inhibition: > 100000 nM
Compound 4: no number, only a limit; the forecaster's own chance of this, stated with the estimate: 65%; at least 1.1-fold (0.04 log units) between middle value and limit.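

Replacing the group of 7 heavy atoms (6 carbon, 1 silicon) with a hydrogen atom, on an oxygen on a saturated carbon, gives in this assay an at least 3.5-fold higher number from compound 2 to compound 4 (0.55 log units; beyond the scatter). Compound 4 gives > 100000 nM, which is a limit and not a number. Compounds 2 and 3 could not show what this group contributes, because the step between them concerns only: the fact that compounds 2 and 3 differ only in the configuration as drawn

As far as these compounds go, whether a methyl ether or an acetyl ester on this oxygen would keep the number of compound 2 stays open. The full size of the step also stays open, because the values reach a ceiling: the limit of > 100000 nM in this assay, at which 2 of the 4 values shown sit.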